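The source may hold more compounds than are shown below. What is called first, only, known or untested is meant among the compounds shown, and "the series" means these compounds.

Compound 1 `O=C(CSc1nnnn1-c1ccccc1)N/N=c1/scc(-c2ccc(Cl)cc2)n1-c1ccccc1`: 54.3%
Compound 2 `Cc1nnc(SCC(=O)N/N=c2/scc(-c3ccc(Cl)cc3)n2-c2ccccc2)s1`: 34.1%
Compound 3 `O=C(CSc1ncccn1)N/N=c1/scc(-c2ccc(Cl)cc2)n1-c1ccccc1`: 45.5%

In a functional assay on C6 cells (Rattus norvegicus) for cytotoxicity, read by MTT assay, with a stated time of 24 h, tested at 100 ug/mL (on this read-out higher numbers stand for a weaker effect at the one concentration tested and lower numbers for a stronger effect), compound 2 gives the lowest of the three numbers, that is the strongest effect: the steps of a number 20.2 percentage points lower from compound 1 to compound 2 (beyond the scatter) and a number 11.4 percentage points higher from compound 2 to compound 3 (beyond the scatter) both lie beyond the scatter, whereas a number 8.8 percentage points lower from compound 1 to compound 3 (within the scatter) lies within it. Compound 4 `Cc1ccc(-c2cs/c(=N/NC(=O)CSc3nnc(C)s3)n2-c2ccccc2)cc1` differs from compound 2 by methyl in place of chloro on an aromatic carbon. For the measured compounds named here, all three measured steps change the group on the sulfur and leave the chlorophenyl ring untouched, so none of them bears directly on this change; the data give no measured step for a swap on that ring. The expected step of a number 3.9 percentage points higher from compound 2 to compound 4 (within the scatter) is therefore small, none beyond the scatter, and carries a wide range. Compound 4 is estimated at 38%, between 22% and 56%.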

Compound 4, a percentage reported as activity, at one concentration (the size of the read-out at that concentration, not a potency): 31.5%
Compound 4: the middle estimate sits 6.5 percentage points above what was measured; the measured number falls inside the stated range.
By their numbers in this assay, from the lowest: compounds 4 and 2 (each within the scatter of the next); then compounds 3 and 1 (each within the scatter of the next).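

Moving from 4-chlorophenyl to 4-methylphenyl gives a number 2.6 percentage points lower from compound 2 to compound 4 (within the scatter) in this assay and is the first measured change on this ring rather than on the sulfur. At this place, para to a large group, chloro and methyl cannot be told apart in this read-out when 5-methyl-1,3,4-thiadiazol-2-yl sits on the sulfur. Nothing measured here explains this likeness.

On these data alone, whether an amine or a carboxylic acid at this position would shift the number remains open. So does whether the swap behaves the same with pyrimidin-2-yl or 1-phenyl-1H-tetrazol-5-yl on the sulfur.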